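Phenol Hydrogen Replaced by (4-Methylphenyl)sulfonyl: An Expectation

The source may hold more compounds than are shown below. What is called first, only, known or untested is meant among the compounds shown, and "the series" means these compounds.

Compound 1, `COc1ccc(-c2cn(C[C@H]3c4c(ccc(OS(=O)(=O)c5ccc(C)cc5)c4C)[C@@H]4CC[C@@]5(C)C[C@]43CC5=O)nn2)cc1`, gives > 20000 nM in a functional assay on HL-60 cells (Homo sapiens) for cytotoxicity, read by MTT assay, with a stated time of 4 days; a lower number here means a stronger inhibitor, a higher number a weaker inhibitor; this is a limit of the assay, not a number. Compound 2, `Cc1ccc(-c2cn(C[C@H]3c4c(ccc(O)c4C)[C@@H]4CC[C@@]5(C)C[C@]43CC5=O)nn2)cc1`, gives > 20000 nM in this assay; this too is a limit and not a number.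

For the measured compounds named here, compound 2 therefore stands at the same limit as compound 1 (the limit of > 20000 nM in this assay, at which 2 of the 2 values shown sit), and no step between measured compounds can be read from these two values. Compound 3, `Cc1ccc(-c2cn(C[C@H]3c4c(ccc(OS(=O)(=O)c5ccc(C)cc5)c4C)[C@@H]4CC[C@@]5(C)C[C@]43CC5=O)nn2)cc1`, differs from compound 2 by (4-methylphenyl)sulfonyl in place of hydrogen on an oxygen on an aromatic ring. Compound 1 already carries this sulfonyl group and sits at the limit (the limit of > 20000 nM in this assay, at which 2 of the 2 values shown sit), so no step beyond the scatter is expected from compound 2 to compound 3, and compound 3 is expected to remain at the limit as well. The estimated step is a step that the limit leaves unreadable from compound 2 to compound 3. The expected value for compound 3 is 25000 nM, with a range from 8000 nM to 80000 nM.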

Compound 3, half-maximal inhibitory concentration: > 20000 nM
Compound 3 ended at the assay's limit; the forecaster's own chance of this, stated with the estimate: 80%; the middle value is on the limit's open side.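

In this assay compound 3 gives > 20000 nM and this is a limit, not a number. For the compounds shown here, no step to compound 3 from compound 1 or compound 2 can be read. The compounds shown leave open whether (4-methylphenyl)sulfonyl in place of hydrogen, or methyl in place of methoxy, changes the result in this assay at all.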